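The source may report more compounds than this note shows. Statements on the series, on what has been measured and on what is new or still open speak of the compounds shown alone.

Measured so far in a functional assay on PC-3 cells (Homo sapiens) for inhibition, read by sulforhodamine B assay; on this read-out higher numbers stand for weaker inhibition of growth and lower numbers for stronger inhibition of growth:
- compound 1 `Fc1ccc(-c2ccc(-c3ccc(-c4nc5ccccc5[nH]4)cc3)cc2)cc1`: 41200 nM
- compound 2 `FC(F)(F)c1ccc(-c2ccc(-c3ccc(-c4nc5ccccc5[nH]4)cc3)cc2)cc1`: 45200 nM
- compound 3 `COc1ccc(-c2ccc(-c3ccc(-c4nc5ccccc5[nH]4)cc3)cc2)cc1`: 100000 nM

Compound 3 has the highest number of the three at 100000 nM, so it is the weakest growth inhibitor measured in this assay. The next change gives compound 4 `Clc1cccc(-c2ccc(-c3ccc(-c4nc5ccccc5[nH]4)cc3)cc2)c1`, with 3-chlorophenyl in place of 4-methoxyphenyl on an aromatic carbon. Among the compounds with values here, no measured compound carries 3-chlorophenyl, so the closest guide is what happens when methoxy is absent. The relevant steps are a 2.4-fold higher number from compound 1 to compound 3 (0.39 log units; beyond the scatter) and a 2.2-fold higher number from compound 2 to compound 3 (0.34 log units; beyond the scatter), both modest. In contrast, a 1.1-fold higher number from compound 1 to compound 2 (0.04 log units; within the scatter) stays within the scatter, so compound 1 and compound 2 give one level for the two compounds without methoxy. Within the data shown here, with only three values, and none for this group, the expectation is loose. A modest fall in the number is expected, estimated as a 2.2-fold lower number from compound 3 to compound 4 (0.35 log units; beyond the scatter). For compound 4 the estimated value is 45000 nM, with an expected range of 18000 nM to 100000 nM.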

Compound 4, concentration for 50% growth inhibition: 33700 nM
The estimate for compound 4 lay 1.3-fold (0.13 log units) above the measured number; low and high end bracket the measured number.
By their numbers in this assay, from the lowest: compounds 4, 1 and 2 (each within the scatter of the next); then compound 3.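

In this assay, the 3-chlorophenyl group stands level with the two other groups that lack methoxy (a 1.2-fold lower number from compound 1 to compound 4 (0.09 log units; within the scatter); a 1.3-fold lower number from compound 2 to compound 4 (0.13 log units; within the scatter)), so a chlorine placed differently on this aromatic ring leaves compound 4 at the level of compound 1 and compound 2. Within the data shown here, the modest step away from the 4-methoxyphenyl group (a 3.0-fold lower number from compound 3 to compound 4 (0.47 log units; beyond the scatter)) makes compound 3 the one compound apart from that shared level, and it stands against any reading of the four as a single level. No supporting measurement accounts for this difference.

Since the group and its point of attachment changed together, the compounds shown cannot separate the effect of chlorine from that of its placement. On these data alone, it also remains open whether an amine or a carboxylic acid at this position would move the number away from this level.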